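Halogen and chain changes on the thioether side chain

The compounds below may be only part of what the source reports. "The series", "measured", "known", "first", "only" and "open" are said of these compounds alone.

Going by the values given here, compound 1 `Cn1c(=O)c2c(nc(SCCc3ccc(Br)cc3)n2C)n(C)c1=O` gives 108000 nM in an assay on microsomes for inhibition of Amine oxidase [flavin-containing] A (Homo sapiens), read by fluorescence and spectrophotometry, with a stated time of 20 min (a lower number here means a stronger inhibitor, a higher number a weaker inhibitor), the highest of the two numbers measured so far; the nearest is compound 2 `Cn1c(=O)c2c(nc(SCCc3ccc(F)cc3)n2C)n(C)c1=O`, which gives 14700 nM, so that a 7.3-fold lower number from compound 1 to compound 2 (0.87 log units; beyond the scatter). Compound 3 `Cn1c(=O)c2c(nc(SCCCc3cccc(Cl)c3)n2C)n(C)c1=O` is not yet measured; it differs from compound 1 by 3-chlorobenzyl in place of 4-bromophenyl on a saturated chain carbon, two bonds along the chain from a sulfur. Among the compounds with values here, the one measured step bears on this only in part, since it swaps the halogen while the chain stays; the longer chain has no precedent in this set. A lower number than for compound 1 is expected, with a step of a 2.7-fold lower number from compound 1 to compound 3 (0.43 log units; beyond the scatter). Compound 3 is estimated at 40000 nM, with a range from 8000 nM to 200000 nM.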

Compound 3, half-maximal inhibitory concentration: 3530 nM
Compound 3: the middle estimate sits 11-fold (1.05 log units) above what was measured; the measured number lies below the stated range.
By their numbers in this assay, from the lowest: compound 3; then compound 2; then compound 1.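

On this saturated chain carbon, two bonds along the chain from a sulfur, 3-chlorobenzyl outperforms both earlier groups in this assay, giving a 31-fold lower number from compound 1 to compound 3 (1.49 log units; beyond the scatter) and a 4.2-fold lower number from compound 2 to compound 3 (0.62 log units; beyond the scatter). Compound 3 therefore has the lowest number of the three, and the gain over 4-fluorophenyl shows that the halogen swap between compound 1 and compound 2 did not exhaust what this side chain can give. No evidence on the origin of these steps is available.

Chain length, halogen identity and halogen placement all change together here, so their separate contributions remain unresolved. Also open, on these data alone, is how an amine, a carboxylic acid or a still longer chain would read at this position.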